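Isopropyl for Bromine on the Aniline Ring of Compound 1

The source may report more compounds than this note shows. Statements on the series, on what has been measured and on what is new or still open speak of the compounds shown alone.

Measured compounds:
compound 1 `CNC(=O)c1ccccc1Oc1nc(Nc2cccc(Br)c2)ncc1Br` — 38700 nM
compound 2 `CNC(=O)c1ccccc1Oc1nc(Nc2ccccc2OC)ncc1Br` — > 50000 nM

Of the compounds shown here, two have been measured in a functional assay on HL-60 cells (Homo sapiens) for antiproliferative activity, read by MTT assay, with a stated time of 24 h; a higher number here means a weaker inhibitor, a lower number a stronger inhibitor. Compound 1 `CNC(=O)c1ccccc1Oc1nc(Nc2cccc(Br)c2)ncc1Br` gives 38700 nM in this assay, and this is the only plain number shown. Compound 2 `CNC(=O)c1ccccc1Oc1nc(Nc2ccccc2OC)ncc1Br` gives > 50000 nM in this assay, which is a limit of the assay and not a number (the limit of > 50000 nM in this assay, at which 1 of the 2 values shown sits). Going by the values given here, the one step that can be stated, an at least 1.2-fold higher number from compound 1 to compound 2 (0.11 log units; that floor lies within the scatter), changes the group on the aromatic nitrogen, and its floor sits inside the scatter.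

Compound 3 `CNC(=O)c1ccccc1Oc1nc(Nc2cccc(C(C)C)c2)ncc1Br` has not been measured. It differs from compound 1 by isopropyl in place of bromo on an aromatic carbon. No measured step touches this part of the molecule: the only step shown concerns a different group and does not reach beyond the scatter. There is therefore no basis for expecting a shift in either direction beyond the scatter, and a value near that of compound 1 is the natural expectation, with the limit of the assay not far off.

For compound 3 the expected value in this assay is 40000 nM, with a range from 13000 nM to 120000 nM, which means an expected step of a 1.0-fold higher number from compound 1 to compound 3 (0.01 log units; within the scatter).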

Compound 3, half-maximal inhibitory concentration: 17500 nM
Beside the measured number, compound 3's estimate is 2.3-fold (0.36 log units) above it, and the stated range covers the measured number.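

In this assay, isopropyl in place of bromo on an aromatic carbon, meta to a large group, gives a 2.2-fold lower number from compound 1 to compound 3 (0.34 log units; beyond the scatter). Going by these compounds alone, this shows that the number responds to the group at this place on the ring, which the earlier pair could not show, as the floor of its only step stayed within the scatter. The step of an at least 2.8-fold lower number from compound 2 to compound 3 (0.45 log units; beyond the scatter) also lies beyond the scatter, but it is only a floor, as compound 2 stands at a limit of the assay and not a number: the limit of > 50000 nM in this assay, at which 1 of the 3 values shown sits.

The compounds shown do not tell why isopropyl gives a lower number than bromo, and one modest step at a single place is too little to build a trend on. Other groups at this same place, such as a methyl, a tert-butyl, an amine or a carboxylic acid, would show whether the number keeps falling with a larger carbon group or whether the gain is particular to isopropyl.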